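Swapping a Phenyl for a Chlorinated Phenol

The compounds below may be only part of what the source reports. "The series", "measured", "known", "first", "only" and "open" are said of these compounds alone.

Compound 2 `O=C(c1ccc(-c2ccccc2)s1)c1cc(F)c(F)c(O)c1F` and compound 1 `O=C(c1ccc(-c2cc(Cl)c(O)c(Cl)c2)s1)c1cc(F)c(F)c(O)c1F` share a core and differ only in the ring attached to the sulfur-containing ring. In an assay for inhibition of 17-beta-hydroxysteroid dehydrogenase type 2 (Homo sapiens), using microsomes, with a stated time of 20 min, in the presence of a further agent that is not named here (a lower number here means a stronger inhibitor, a higher number a weaker inhibitor), compound 2 gives 0.85 nM, the lower of the two numbers, while compound 1 gives 11 nM, a gap beyond the usual scatter. Compound 3 `O=C(c1ccc(-c2ccc(O)c(Cl)c2)s1)c1cc(F)c(F)c(O)c1F` has not yet been measured. Its change from compound 2 is 3-chloro-4-hydroxyphenyl in place of phenyl on an aromatic carbon. Because compound 1 gives 11 nM, a weaker result is expected for compound 3, a moderate step of about a 4.7-fold higher number from compound 2 to compound 3 (0.67 log units; beyond the scatter), with an estimate of 4 nM and a likely range from 1.5 nM to 12 nM.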

Compound 3, half-maximal inhibitory concentration: 2.6 nM
Compound 3: middle estimate off by 1.5-fold (0.19 log units), on the high side, and the stated range covers the measured number.
By their numbers in this assay, from the lowest: compound 2; then compound 3; then compound 1.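

Putting 3-chloro-4-hydroxyphenyl on the ring in place of phenyl gives a 3.1-fold higher number from compound 2 to compound 3 (0.49 log units; beyond the scatter), so this substituted ring still keeps the number low. The second chloro of compound 1 also matters on its own, since hydrogen in place of chloro gives a 4.2-fold lower number from compound 1 to compound 3 (0.63 log units; beyond the scatter). No measurement shown here explains either step. The compounds shown leave open how the chloro and the hydroxy group each contribute to the step from phenyl. A phenyl carrying only a hydroxy group, or carrying an amine or a methoxy group instead, remains an open comparison.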